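From 3-nitrophenyl to phenyl: a step off a limit

The compounds below may be only part of what the source reports. "The series", "measured", "known", "first", "only" and "open" are said of these compounds alone.

Measured in a functional assay on HT-29 cells (Homo sapiens) for inhibition, read by MTT assay, with a stated time of 48 h; a lower number here means a stronger inhibitor, a higher number a weaker inhibitor:
compound 1 `COc1cc(-c2cc(-c3ccc(Cl)cc3)nc(-c3ccccc3)n2)cc(OC)c1OC`: 6230 nM
compound 2 `COc1cc(-c2cc(-c3cccc([N+](=O)[O-])c3)nc(-c3ccccc3)n2)cc(OC)c1OC`: > 25000 nM (a limit)
compound 3 `COc1cc(-c2cc(-c3ccc(C)cc3)nc(-c3ccccc3)n2)cc(OC)c1OC`: > 25000 nM (a limit)

Compound 2 has no number, only the limit > 25000 nM. The series shows (the limit of > 25000 nM in this assay, at which 2 of the 3 values shown sit).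

Compound 4 `COc1cc(-c2cc(-c3ccccc3)nc(-c3ccccc3)n2)cc(OC)c1OC` differs from compound 2 by hydrogen in place of nitro on an aromatic carbon, meta to a large group.

Going by the values given here, two measured steps bear on this change. The first is an at least 4.0-fold higher number from compound 1 to compound 2 (0.60 log units; beyond the scatter), and the second, with methyl in place of chloro, is an at least 4.0-fold higher number from compound 1 to compound 3 (0.60 log units; beyond the scatter). Both lie beyond the scatter, but both are one-sided, and neither leaves the ring without a substituent. The step that the two limits leave unreadable from compound 2 to compound 3 adds no size. Only compound 1 gives a number in this assay, 6230 nM, and compound 4 lacks its chloro. Compound 4 is therefore expected to sit closer to the limit than to compound 1, and a further limit is about as likely as a number. Any readable step is expected to be small and towards a lower number.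

The estimated value for compound 4 is 22000 nM, with an expected range of 9000 nM to 50000 nM. This estimate corresponds to an expected at least 1.1-fold lower number from compound 2 to compound 4 (0.05 log units; that floor lies within the scatter).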

Compound 4, half-maximal inhibitory concentration: 7930 nM
Beside the measured number, compound 4's estimate is 2.8-fold (0.44 log units) above it; measured number below the stated range.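

In this assay, compound 4 turns the nitro position from a limit into a number, and the ring with no substituent at all reads clearly better than the nitro compound: an at least 3.1-fold lower number from compound 2 to compound 4 (0.49 log units; beyond the scatter). The methyl compound gives the same picture, an at least 3.1-fold lower number from compound 3 to compound 4 (0.49 log units; beyond the scatter), while hydrogen in place of chloro gives a 1.3-fold higher number from compound 1 to compound 4 (0.10 log units; within the scatter), so compound 1 and compound 4 cannot be told apart and the chloro is not needed for a measurable value. Among the compounds shown, no substituent on this ring improves on hydrogen, and the 3-nitrophenyl and 4-methylphenyl compounds are the two that remain at the limit: the limit of > 25000 nM in this assay, at which 2 of the 4 values shown sit.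

From the compounds shown here alone, the true size of the nitro and methyl steps stays open, as both are one-sided, and the step between compound 2 and compound 3 cannot be read. Also open, going by these compounds, is whether an amine or a carboxylic acid in place of hydrogen on this ring would give a number lower than those of compound 1 and compound 4.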